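Shrinking the Cyclohexyl Ring on a Shared Core

This account rests on a few compounds, and the source may have more. Where it says the series, first, only, none or still open, it means among the compounds named here.

Measured so far:
- compound 1, `Nc1ccc2cccc(OCCC3CCCCC3)c2n1`: 808 nM
- compound 2, `Nc1ccc2cccc(OCC3CCCO3)c2n1`: > 2000 nM
- compound 3, `COC(C)(C)CCOc1cccc2ccc(N)nc12`: 132 nM

In an assay on cells with melanin-concentrating hormone receptor 1 (Homo sapiens) as the target, read by radioligand binding (on this read-out lower numbers stand for stronger inhibition and higher numbers for weaker inhibition), compound 1 gives 808 nM. Compound 3 gives 132 nM, and of the two numbers available compound 1 stands highest. For compound 2 the assay returns only a limit, > 2000 nM, so no number is known for it; this is the situation described by the limit of > 2000 nM in this assay, at which 1 of the 3 values shown sits.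

Compound 4, `Nc1ccc2cccc(OCCC3CC3)c2n1`, differs from compound 1 in one place: cyclopropyl in place of cyclohexyl on a saturated chain carbon, two bonds along the chain from an oxygen on an aromatic ring. Among the compounds with values here, two measured steps touch this region of the core. The step of a 6.1-fold lower number from compound 1 to compound 3 (0.79 log units; beyond the scatter) exchanged the cyclohexyl for an open chain carrying a methoxy group at the same position, a modest gain. The step of an at least 15-fold lower number from compound 2 to compound 3 (1.18 log units; beyond the scatter) swapped an oxolan-2-yl ring for a chain at the carbon bound to the aromatic oxygen, a large gain. Neither step replaces a six-membered carbon ring with a smaller carbon ring, so they give no direct guide, and the change in compound 4 is far smaller than either of them in kind.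

Compound 4 is therefore expected to stay in the range of compound 1, with a step of a 1.9-fold higher number from compound 1 to compound 4 (0.27 log units; within the scatter), and an estimated value of 1500 nM, between 400 nM and 5000 nM.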

Compound 4, half-maximal inhibitory concentration: 492 nM
Compound 4: the middle estimate sits 3.0-fold (0.48 log units) above what was measured; the measured number falls inside the stated range.
By their numbers in this assay, from the lowest: compound 3; then compounds 4 and 1 (each within the scatter of the next). At a limit, above all of these: compound 2.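

Going from cyclohexyl to cyclopropyl takes the group from 6 heavy atoms to 3, yet in this assay the two compounds cannot be told apart: a 1.6-fold lower number from compound 1 to compound 4 (0.22 log units; within the scatter). At this position, then, these two carbon rings give the same picture, and the size of the ring does not decide the reading, at least between these two sizes. Compound 3 stays clearly apart from the small ring as it did from the large one, a 3.7-fold higher number from compound 3 to compound 4 (0.57 log units; beyond the scatter), so neither carbon ring matches its 1-methoxy-1-methylethyl group, while the value of compound 2 is a limit and not a number, and its step to the cyclopropylmethyl chain is read against that limit, an at least 4.0-fold lower number from compound 2 to compound 4 (0.60 log units; beyond the scatter): the limit of > 2000 nM in this assay, at which 1 of the 4 values shown sits.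

Still open, as far as these compounds go, is how a branched carbon group without the methoxy oxygen, such as tert-butyl, would compare with compound 3, a comparison that would separate the effect of the oxygen from that of the branching. Also open, from the compounds shown here alone, is what an amine or a carboxylic acid at this place on the chain would do to the reading.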